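A few compounds are considered here, and "the series" means these few. Any claim that something is new, unique, unknown or untested is made for them only; others in the source may bear on it.

Measured so far in an assay on HeLa cells for inhibition of sphingosine-1-phosphate transporter SPNS2 (Mus musculus), read by LC-MS, tested at 2 uM; a higher number here means more inhibition at the concentration tested (going by the name of the read-out), a lower number less inhibition:
compound 1, `CCCCCCCCCCc1ccc(-c2noc(CCCN)n2)cc1` — 67%
compound 2, `CCCCCCCCCCc1ccc(-c2noc(CCCN(C)C)n2)cc1` — 8%

Among the measured compounds shown here, compound 2 stands lowest of the two numbers; its nearest neighbour is compound 1, and the only measured step is a number 59 percentage points lower from compound 1 to compound 2 (beyond the scatter), a large fall that lies beyond the scatter. That step exchanged a group with a hydrogen-bond donor for one without, at the chain end three bonds from the aromatic carbon.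

Compound 3, `CCCCCCCCCCc1ccc(-c2noc(CC3CCNC3)n2)cc1`, has not yet been measured. Against compound 2 the change is pyrrolidin-3-yl in place of 2-(dimethylamino)ethyl on a saturated chain carbon bound to an aromatic carbon. The group that enters carries one hydrogen-bond donor and one acceptor, where the group that leaves carries no donor and one acceptor; in that respect the change runs partly back toward compound 1, though now the nitrogen sits inside a five-membered non-aromatic ring rather than on an open chain. For the measured compounds named here, the step from compound 1 to compound 2 bears on this, and its size suggests that restoring a donor could recover a good part of the lost inhibition, but the ring is new to the series and no measured step tells how much it matters. Compound 3 is therefore expected to rise from compound 2 by a number 32 percentage points higher from compound 2 to compound 3 (beyond the scatter), landing between compound 2 and compound 1. The estimate for compound 3 in this assay is 40%, with a range from 10% to 70%.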

Compound 3, a percentage reported as inhibition, at one concentration (the size of the read-out at that concentration, not a potency): 44%
Compound 3: middle estimate off by 4 percentage points, on the low side; the measured number falls inside the stated range.
By their numbers in this assay, from the lowest: compound 2; then compound 3; then compound 1.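

In this assay, the place on a saturated chain carbon bound to an aromatic carbon accepts a ring: pyrrolidin-3-yl in place of 2-(dimethylamino)ethyl gives a number 36 percentage points higher from compound 2 to compound 3 (beyond the scatter) and so regains much of the ground lost with the dimethylamino end. The ring does not fully match the open chain, however, since pyrrolidin-3-yl in place of 2-aminoethyl gives a number 23 percentage points lower from compound 1 to compound 3 (beyond the scatter) with the shared core unchanged. Both compounds with a hydrogen-bond donor in this group stand above compound 2, yet the presence of a donor alone does not bring compound 3 level with compound 1, and nothing on hand accounts for either step.

The compounds shown leave open whether the recovery follows the donor or the ring, since these two changes arrive together in compound 3; a methylamino end on the open chain and a 1-methylpyrrolidin-3-yl group would pull them apart. Also open, as far as these compounds go, is how the same place responds to a larger piperidin-4-yl ring or to a carboxylic acid in place of the amine.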